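Removing the hydroxymethyl from compound 2: half-life notes

The source may report more compounds than this note shows. Statements on the series, on what has been measured and on what is new or still open speak of the compounds shown alone.

compound 1 `CC(C)c1ccc2c(Nc3cc(C(=O)N[C@@H](C)C4CCCCC4)ccc3Sc3ccc(N)cc3)ncnc2n1`: 0.5 h
compound 2 `CC(C)c1ccc2c(Nc3cc(C(=O)N[C@@](C)(CO)c4ccccc4)ccc3Sc3ccc(N)cc3)ncnc2n1`: 1.1 h

In an ADME assay on the whole organism (strain Sprague-Dawley) for metabolic stability, with Rattus norvegicus as the target, at a dose of 5 mg/kg by the intravenous route (on this read-out lower numbers stand for a shorter-lived compound and higher numbers for a longer-lived compound), compound 1 gives 0.5 h and compound 2 gives 1.1 h. Among the measured compounds shown here, compound 2 stands highest of the two numbers measured so far; its nearest neighbour is compound 1, and the step of a 2.2-fold higher number from compound 1 to compound 2 (0.34 log units; beyond the scatter) lies beyond the scatter. That single step exchanges a cyclohexyl-bearing group for one carrying both a phenyl and a hydroxymethyl, so the two parts of the change cannot be separated from the numbers alone.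

Compound 3 `CC(C)c1ccc2c(Nc3cc(C(=O)N[C@@H](C)c4ccccc4)ccc3Sc3ccc(N)cc3)ncnc2n1` is not yet measured. It differs from compound 2 by hydrogen in place of hydroxymethyl on a saturated chain carbon bound to an amide-type nitrogen, an aromatic carbon and a saturated chain carbon. For the measured compounds named here, the only measured step that bears on it is a 2.2-fold higher number from compound 1 to compound 2 (0.34 log units; beyond the scatter), and that step brings the hydroxymethyl in together with the ring change; no measured pair isolates the hydroxymethyl by itself. Compound 3 keeps the aromatic ring of compound 2 and drops the hydroxymethyl, so a number between those of compound 1 and compound 2 is the working expectation. The step is expected to be a 1.5-fold lower number from compound 2 to compound 3 (0.17 log units; within the scatter), within the scatter. Compound 3 is therefore estimated at 0.75 h, with a range of 0.4 h to 1.4 h.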

Compound 3, half-life in the Rattus norvegicus assay: 1.6 h
Estimate against measurement, compound 3: 2.1-fold (0.33 log units) below, and the stated range ends below it.
By their numbers in the Rattus norvegicus assay, from the lowest: compound 1; then compounds 2 and 3 (each within the scatter of the next).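

On the half-life read-out of the Rattus norvegicus assay, hydrogen in place of hydroxymethyl on this saturated chain carbon gives a 1.5-fold higher number from compound 2 to compound 3 (0.16 log units; within the scatter), so the hydroxymethyl itself is not resolved as a contributor to half-life at this position. The pair that isolates the ring gives a 3.2-fold higher number from compound 1 to compound 3 (0.51 log units; beyond the scatter) for phenyl in place of cyclohexyl, and this step, which the earlier comparison left mixed with the hydroxymethyl, lies beyond the scatter. The same hydroxymethyl does register in solubility, where in a physicochemical assay for solubility (on this read-out higher numbers stand for higher solubility and lower numbers for lower solubility), compound 2 gives 19700 nM and compound 3 gives 5000 nM, so at this carbon its loss lowers solubility with no resolved shift in half-life: the measured solubility of compound 2, 19700 nM, and of compound 3, 5000 nM, a 3.9-fold lower number (0.60 log units; beyond the scatter)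

As far as these compounds go, whether a methoxymethyl or an aminomethyl on this saturated chain carbon would keep the solubility of compound 2 while holding the half-life of compound 3 stays open. Also open, from the compounds shown here alone, is whether the ring step holds when the hydroxymethyl is present, which would take a cyclohexyl carrying a hydroxymethyl on the same carbon to compare with compound 2.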